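The source may report more compounds than this note shows. Statements on the series, on what has been measured and on what is new or still open speak of the compounds shown alone.

Measured so far:
Compound 1, `O=C(Cc1cccnc1)c1cc2cc(-c3ccccc3)ccc2[nH]1`, gives 96000 nM in an assay on isolated protein for inhibition of Indoleamine 2,3-dioxygenase 1 (Homo sapiens), read by spectrophotometry; a higher number here means a weaker inhibitor, a lower number a stronger inhibitor.
Compound 2, `O=C(Cc1cccnc1)c1cc2cc(F)ccc2[nH]1`, gives 36000 nM in this assay.

Among the measured compounds shown here, compound 2 holds the lower of these two numbers; its only neighbour is compound 1, and the step of a 2.7-fold lower number from compound 1 to compound 2 (0.43 log units; beyond the scatter) separates them. Compound 3, `Cc1ccc2[nH]c(C(=O)Cc3cccnc3)cc2c1`, has not yet been measured. It differs from compound 2 by one small swap: methyl in place of fluoro on an aromatic carbon. For the measured compounds named here, only one measured step touches this position, the exchange of phenyl for fluoro, which lowered the number modestly (a 2.7-fold lower number from compound 1 to compound 2 (0.43 log units; beyond the scatter)). That step set a large group against one of a single heavy atom, whereas here one group of a single heavy atom gives way to another, so it offers no direct guide. For compound 3 in this assay no movement beyond the scatter is expected, and the estimate is 40000 nM, between 15000 nM and 110000 nM, which amounts to a 1.1-fold higher number from compound 2 to compound 3 (0.05 log units; within the scatter).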

Compound 3, half-maximal inhibitory concentration: 87000 nM
Beside the measured number, compound 3's estimate is 2.2-fold (0.34 log units) below it; the range from low to high includes it.
By their numbers in this assay, from the lowest: compound 2; then compounds 3 and 1 (each within the scatter of the next).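

At this position, the number of heavy atoms in the group does not settle the result: swapping one single-atom group for another gives a 2.4-fold higher number from compound 2 to compound 3 (0.38 log units; beyond the scatter) in this assay, a step of about the same size as the earlier change from phenyl to fluoro. The much larger phenyl and the small methyl cannot be told apart, since a 1.1-fold lower number from compound 1 to compound 3 (0.04 log units; within the scatter) shows no real change, so compound 3 goes against any simple rule that a smaller group gives a lower number, and among these three only the fluoro compound stands apart. Nothing available explains why fluoro and methyl differ here.

As far as these compounds go, it remains open whether a chloro, hydroxyl or amino group at this position would behave like fluoro or like methyl. From the compounds shown here alone, it is also open whether fluoro would keep its advantage on another aromatic carbon of the shared core.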